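The source may hold more compounds than are shown below. What is called first, only, known or untested is meant among the compounds shown, and "the series" means these compounds.

Measured in a functional assay on LoVo cells (Homo sapiens) for inhibition, read by MTT assay, with a stated time of 48 h; on this read-out higher numbers stand for weaker inhibition and lower numbers for stronger inhibition:
- compound 1 `COc1ccc(N(C)c2nc(C)nc3ccccc23)cc1OCCC[Se]C#N`: 921 nM
- compound 2 `C[Se]c1ccc(N(C)c2nc(C3CC3)nc3ccccc23)cc1`: 11 nM

Compound 1 has the higher number of the two, and its gap to compound 2 lies beyond the scatter. Compound 3 `COc1ccc(N(C)c2nc(C)nc3ccccc23)cc1C(=O)OCC[Se]C#N` has not yet been measured in this assay. It departs from compound 1 at one place, on an aromatic carbon, ortho to a methoxy group: a group of 8 heavy atoms (4 carbon, 1 nitrogen, 2 oxygen, 1 selenium; no ring) in place of a group of 7 heavy atoms (4 carbon, 1 nitrogen, 1 oxygen, 1 selenium; no ring), on an aromatic carbon. Going by the values given here, no measured pair shows this change alone, so the expectation rests on compound 1 at 921 nM, with no step beyond the scatter anticipated. The estimated step is a 1.3-fold higher number from compound 1 to compound 3 (0.11 log units; within the scatter). For compound 3 the expected value is 1200 nM, with an estimated range of 300 nM to 5000 nM.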

Compound 3, half-maximal inhibitory concentration: 2960 nM
Compound 3: the middle estimate sits 2.5-fold (0.39 log units) below what was measured; the measured number falls inside the stated range.
By their numbers in this assay, from the lowest: compound 2; then compound 1; then compound 3.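

In this assay the change on the aromatic carbon ortho to a methoxy group, a group of 8 heavy atoms in place of a group of 7 heavy atoms, gives a 3.2-fold higher number from compound 1 to compound 3 (0.51 log units; beyond the scatter) and so counts as a modest loss. This position therefore responds to a small change in the group it carries, which compound 2 could not show, as it differs from compound 1 in more than one place. No measurement here bears on what lies behind this step.

Going by these compounds, whether the loss follows the added carbonyl or the altered link to the aromatic carbon remains open. An amide link or a longer chain at this carbon would help separate the two.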